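The compounds below may be only part of what the source reports. "The series", "measured", "known", "first", "only" and "open" are said of these compounds alone.

Three compounds sharing one core were examined in a functional assay on C6 cells (Rattus norvegicus) for cytotoxicity, read by MTT assay, with a stated time of 24 h, tested at 12 ug/mL; a lower number here means a stronger effect, a higher number a weaker effect of the compound at the concentration tested. Compound 1, `O=C(CSc1ncccn1)N/N=c1/scc(-c2ccc(Br)cc2)n1-c1ccccc1`, gives 72.1% in this assay, the highest of the three numbers and so the weakest effect among them. Compound 3, `O=C(CSc1nnnn1-c1ccccc1)N/N=c1/scc(-c2ccc(F)cc2)n1-c1ccccc1`, gives 60%, a number lower than that of compound 1 by more than the scatter. Compound 2, `COc1ccc(-c2cs/c(=N/NC(=O)CSc3nnc(C)s3)n2-c2ccccc2)cc1`, gives 53.6%, the lowest of the three and furthest from compound 1, again by more than the scatter. No two of these compounds differ in only one place, so no single step between measured compounds can be read off.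

Compound 4, `Cc1ccc(-c2cs/c(=N/NC(=O)CSc3ncccn3)n2-c2ccccc2)cc1`, is not yet measured. It differs from compound 1 in one respect: methyl in place of bromo on an aromatic carbon. Within the data shown here, nothing among the measured compounds isolates this exchange. In the absence of such a comparison, the change from compound 1 to compound 4 is expected to give a step in this assay that stays within the scatter, and the direction, if any, is expected to be slightly downward, a number 5.1 percentage points lower from compound 1 to compound 4 (within the scatter). Compound 4 is therefore estimated at 67%, with a range from 50% to 84%.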

Compound 4, a percentage reported as activity, at one concentration (the size of the read-out at that concentration, not a potency): 83%
For compound 4 the middle estimate is 16 percentage points below the measured one, within the range that was stated.
By their numbers in this assay, from the lowest: compounds 2 and 3 (each within the scatter of the next); then compound 1; then compound 4.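

In this assay, the exchange of 4-bromophenyl for 4-methylphenyl gives a number 10.9 percentage points higher from compound 1 to compound 4 (beyond the scatter) and so moves the read-out by a modest amount. The group on this aromatic carbon, para to a large group, therefore bears on the result: with the rest of compound 1 unchanged, methyl leaves a weaker effect than bromo at the concentration tested. The earlier compounds differ from one another in more than one place and could not show this, and nothing measured here explains the step.

The compounds shown leave open how an amine or a carboxylic acid on this aromatic carbon would read. They also leave open whether methyl in place of the group found there would shift the number in the same direction with the remaining structure of compound 2 or compound 3.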